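A few compounds are considered here, and "the series" means these few. Any claim that something is new, unique, unknown or untested is made for them only; others in the source may bear on it.

Compound 1, with the structure `CCN(Cc1ccc(C)s1)C(=O)COc1ccc(C)cc1`, was tested in an assay on HEK293 cells for agonist activity at transient receptor potential cation channel subfamily M member 8 (Homo sapiens), read by fluorescence and calcium flux, with a stated time of 15 min (a lower number here means that less compound is needed, a higher number that more compound is needed for the effect), and gave 178 nM. Going by the values given here, that is the highest of the two numbers measured so far. Among the compounds with values here, the only other measured compound is compound 2, whose structure is `O=C(COc1ccc2c(c1)CCC2)N(Cc1cccs1)c1ccn[nH]1`; in this assay compound 2 gave 0.001 nM, a far lower number, and the gap between the two lies well beyond the usual scatter. The two differ in several places at once, so nothing about any single change can be read from that pair.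

Compound 3, with the structure `CCN(Cc1ccncc1)C(=O)COc1ccc(C)cc1`, has not yet been measured in this assay. It differs from compound 1 in one place only: pyridin-4-yl in place of 5-methylthiophen-2-yl on a saturated chain carbon bound to an amide-type nitrogen. Within the data shown here, no measured pair shows this change. The step from compound 1 to compound 3 is therefore expected to be modest, a 2.2-fold higher number from compound 1 to compound 3 (0.35 log units; beyond the scatter), and may fall within the scatter. Compound 3 is expected to give 400 nM, with a likely range from 80 nM to 2000 nM.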

Compound 3, half-maximal effective concentration: "not active" (no number reported)
Nothing numeric was reported for compound 3; there is nothing to compare the estimate with.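

Going by these compounds alone, compound 3 is reported as not active in this assay without a number, and no step from compound 1 to compound 3 can be read. Nothing available explains this result. The compounds shown leave open how large this change is and whether pyridin-4-yl would give the same outcome on another core.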